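The compounds below may be only part of what the source reports. "The series", "measured", "known", "first", "only" and "open" are said of these compounds alone.

Measured compounds in an assay on HEK293 cells for inhibition of acid ceramidase (Homo sapiens), read by fluorescence, with stated times of 10 min and 3 h; a lower number here means a stronger inhibitor, a higher number a weaker inhibitor:

- compound 1 `CC(=O)N1CCC(c2ccc3c(c2)oc(=O)n3C(=O)NCCCCc2ccccc2)CC1`, giving 64 nM
- compound 2 `O=C(NCCCCc1ccccc1)n1c2c(oc1=O)CNCC2`, giving 340 nM
- compound 3 `CN1CCC(c2ccc3c(c2)oc(=O)n3C(=O)NCCCCc2ccc(F)cc2)CC1`, giving 94 nM

Compound 1 has the lowest number of the three in this assay. Compound 3 sits nearest to it, within the usual scatter, so no order between compound 1 and compound 3 can be read from these two values. Among the measured compounds shown here, compound 2 is the furthest away, with a gap that lies beyond the scatter; compound 2 also differs from compound 1 in more than one place, so no single step can be assigned to that gap.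

Compound 4 `CC(C)CN1CCC(c2ccc3c(c2)oc(=O)n3C(=O)NCCCCc2ccccc2)CC1` has not been measured in this assay. Relative to compound 1 the change is isobutyl in place of acetyl on an amine nitrogen in a ring. For the measured compounds named here, no measured pair in this set isolates this change. Going by the values given here, the only related observation is compound 3, which carries a methyl on the same amine nitrogen in a ring together with a second change elsewhere, and which gives a value within the scatter of compound 1 in this assay.

On that basis the step from compound 1 to compound 4 is expected to be small, a 1.2-fold higher number from compound 1 to compound 4 (0.07 log units; within the scatter), in no clear direction beyond the scatter. Compound 4 is therefore estimated at 75 nM in this assay, with a range from 25 nM to 220 nM.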

Compound 4, half-maximal inhibitory concentration: 120 nM
Compound 4: the middle estimate sits 1.6-fold (0.20 log units) below what was measured, within the range that was stated.
By their numbers in this assay, from the lowest: compounds 1, 3 and 4 (each within the scatter of the next); then compound 2.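

The step for isobutyl in place of acetyl on an amine nitrogen in a ring in this assay is a 1.9-fold higher number from compound 1 to compound 4 (0.27 log units; within the scatter) and gives the series its first reading that isolates this position. The group that leaves carries a carbonyl and a hydrogen-bond acceptor, while the all-carbon group that enters has no hydrogen-bond acceptor, yet this pair gives no order between the two compounds. This single pair supports no rule for substituents on this nitrogen, and nothing measured here explains the result.

Still open, from the compounds shown here alone, is whether a benzyl group, a longer chain ending in a carboxylic acid, or a plain hydrogen on this nitrogen would give a step beyond the scatter. The effect of methyl alone on the same nitrogen also remains unresolved, since compound 3 carries that group together with a second change elsewhere.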